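Swapping the bromophenyl of compound 1 for a methoxyphenyl

The compounds below may be only part of what the source reports. "The series", "measured", "known", "first", "only" and "open" are said of these compounds alone.

Of the compounds shown here, three sharing one core have been tested in a functional assay on MDA-MB-468 cells (Homo sapiens) for cytotoxicity, with a stated time of 48 h; a higher number here means a weaker inhibitor, a lower number a stronger inhibitor. Compound 1, `O=[N+]([O-])c1ccc(CN2CCC(n3cc(CC(OCc4cc(-c5ccc(Br)cc5)no4)c4ccc(Br)cc4)nn3)CC2)cc1`, gives 5000 nM, the highest of the three numbers. Compound 2, `O=[N+]([O-])c1ccc(CN2CCC(n3cc(CC(OCc4cc(-c5ccc(F)cc5)no4)c4ccc(Br)cc4)nn3)CC2)cc1`, gives 4000 nM, and compound 3, `O=[N+]([O-])c1ccc(CN2CCC(n3cc(CC(OCc4cc(-c5cccc(F)c5)no4)c4ccc(Br)cc4)nn3)CC2)cc1`, gives 3000 nM. The step of a 1.3-fold lower number from compound 1 to compound 2 (0.10 log units; within the scatter) and the step of a 1.7-fold lower number from compound 1 to compound 3 (0.22 log units; within the scatter) both stay inside the usual scatter, so none of these three can be called stronger or weaker than another.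

Compound 4, `COc1cccc(-c2cc(COC(Cc3cn(C4CCN(Cc5ccc([N+](=O)[O-])cc5)CC4)nn3)c3ccc(Br)cc3)on2)c1`, differs from compound 1 in one place: 3-methoxyphenyl in place of 4-bromophenyl on an aromatic carbon. The measured steps that bear on this are those from compound 1 to compound 2 and from compound 1 to compound 3, in which the same 4-bromophenyl was exchanged for another ring without a change beyond the scatter. By the same reasoning the 3-methoxyphenyl of compound 4 is expected to leave this assay roughly where compound 1 stands, the expected step being a 1.4-fold lower number from compound 1 to compound 4 (0.15 log units; within the scatter). Compound 4 is therefore estimated at 3500 nM, with a range from 1500 nM to 8000 nM.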

Compound 4, half-maximal inhibitory concentration: > 25000 nM
Compound 4 was reported as a limit; the forecaster's own chance of this, stated with the estimate: 10%; middle value at least 7.1-fold (0.85 log units) away from the limit.
By their numbers in this assay, from the lowest: compounds 3, 2 and 1 (each within the scatter of the next). At a limit, above all of these: compound 4.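

In this assay, compound 4 is reported only as a limit, not as a number: the limit of > 25000 nM in this assay, at which 1 of the 4 values shown sits.

Even so, the steps are clear: an at least 5.0-fold higher number from compound 1 to compound 4 (0.69 log units; beyond the scatter), an at least 6.2-fold higher number from compound 2 to compound 4 (0.79 log units; beyond the scatter) and an at least 8.3-fold higher number from compound 3 to compound 4 (0.92 log units; beyond the scatter). The earlier ring exchanges stayed within the scatter and could suggest that this place accepts any substituted phenyl, but the new result shows that it does not. The step from compound 3 is the most telling, as only a fluoro changes to a methoxy on the ring.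

From the compounds shown here alone, how large the loss really is remains unknown, as a limit gives only a bound. Going by these compounds, it is also open whether 4-methoxyphenyl would behave like 3-methoxyphenyl, and whether a hydroxy group, an amine or a longer ether such as ethoxy would do the same.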